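Amidine series: hydroxyalkyl versus dimethylaminoethyl on the amine nitrogen

The source may hold more compounds than are shown below. What is called first, only, known or untested is meant among the compounds shown, and "the series" means these compounds.

Three compounds of this core have been run in a functional assay on MDA-MB-231 cells (Homo sapiens) for cytotoxicity, read by MTT assay, with a stated time of 72 h, tested at 5 uM, in the absence of a further agent; a higher number here means a weaker effect of the compound at the concentration tested, a lower number a stronger effect. Compound 1 `CC1(C)CC(N)=Nc2ccc(Cl)cc21` gives 81%. Compound 2 `CC1(C)CC(NCCCCO)=Nc2ccc(Cl)cc21`, carrying 4-hydroxybutyl on the amine nitrogen, gives 84.9%, and the step of a number 3.9 percentage points higher from compound 1 to compound 2 (within the scatter) shows no effect of that chain. Among the compounds with values here, compound 3 `CN(C)CCNC1=Nc2ccc(Cl)cc2C(C)(C)C1` gives 50.8%; on the three numbers so far compound 3 stands lowest, separated from compound 1 by a number 30.2 percentage points lower from compound 1 to compound 3 (beyond the scatter) and from compound 2 by a number 34.1 percentage points lower from compound 2 to compound 3 (beyond the scatter), both steps beyond the scatter.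

Compound 4 `CC1(C)CC(NCCCO)=Nc2ccc(Cl)cc21` is still to be measured. It differs from compound 3 by hydroxymethyl in place of dimethylamino on a saturated chain carbon, two bonds along the chain from an amine nitrogen. Within the data shown here, the one measured step that bears directly on this change is the step from compound 2 to compound 3, where dimethylamino replacing 2-hydroxyethyl lowered the number by a large margin; compound 4 runs that exchange in the opposite sense, and the step from compound 1 to compound 2 suggests a hydroxyalkyl chain on its own leaves the number near that of compound 1. A large step upward in this assay , back toward the values of compounds 1 and 2, is therefore expected. The expected step is a number 29.2 percentage points higher from compound 3 to compound 4 (beyond the scatter). Compound 4 is accordingly estimated at 80%, with a range of 65% to 92%.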

Compound 4, a percentage reported as activity, at one concentration (the size of the read-out at that concentration, not a potency): 84.2%
For compound 4 the middle estimate is 4.2 percentage points below the measured one; the range from low to high includes it.
By their numbers in this assay, from the lowest: compound 3; then compounds 1, 4 and 2 (each within the scatter of the next).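

Hydroxymethyl in place of dimethylamino on a saturated chain carbon, two bonds along the chain from an amine nitrogen, gives a number 33.4 percentage points higher from compound 3 to compound 4 (beyond the scatter), so a second large step in this assay now separates compound 3 from a hydroxyalkyl compound, alongside a number 34.1 percentage points lower from compound 2 to compound 3 (beyond the scatter). Within the hydroxyalkyl pair, the exchange of hydroxymethyl for hydroxy at the chain position three bonds from the amine nitrogen gives a number 0.7 percentage points lower from compound 2 to compound 4 (within the scatter), and 3-hydroxypropyl on the amine nitrogen gives a number 3.2 percentage points higher from compound 1 to compound 4 (within the scatter), so neither the difference between these two chains nor the presence of 3-hydroxypropyl registers beyond the scatter; among the four compounds shown, only compound 3, with its dimethylamino end, stands apart. Nothing at hand explains why the dimethylamino end goes with the lower number.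

As far as these compounds go, it remains open whether that lower number holds for a diethylamino group, a pyrrolidine or a primary amine at the chain end, or for a longer chain such as 3-(dimethylamino)propyl. A methoxy group or a carboxylic acid at the same place would also test how far the hydroxyalkyl result extends, and the single tested concentration leaves potency itself unresolved.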